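The source may report more compounds than this note shows. Statements on the series, on what has been measured and on what is new or still open speak of the compounds shown alone.

Of the compounds shown here, three on a shared core have been measured in a functional assay on A549 cells (Homo sapiens) for antiproliferative activity, tested at 1 uM; a higher number here means more inhibition at the concentration tested (going by the name of the read-out), a lower number less inhibition. Compound 1 `COc1ccc(CO/N=C/c2c(C)nn(C)c2Oc2ccc(Cl)cc2)cc1` gives 43.9%, compound 2 `CCOC(=O)c1ccc(CO/N=C/c2c(C)nn(C)c2Oc2ccc(Cl)cc2)cc1` gives 48.2%, and compound 3 `Cc1nn(C)c(Oc2ccc(Cl)cc2)c1/C=N/OCc1ccc([N+](=O)[O-])cc1` gives 39.6%. Compound 3 stands lowest of the three numbers, but the steps of a number 4.3 percentage points lower from compound 1 to compound 3 (within the scatter) and a number 8.6 percentage points lower from compound 2 to compound 3 (within the scatter) both stay within the scatter, so none of the three is set apart. Compound 4 `COC(=O)c1ccc(CO/N=C/c2c(C)nn(C)c2Oc2ccc(Cl)cc2)cc1` is not yet measured; it differs from compound 3 by methoxycarbonyl in place of nitro on an aromatic carbon. The step of a number 8.6 percentage points lower from compound 2 to compound 3 (within the scatter) bears most directly on this change, and the step of a number 4.3 percentage points higher from compound 1 to compound 2 (within the scatter) also stays inside the scatter. Compound 4 is therefore expected to show a number 6.4 percentage points higher from compound 3 to compound 4 (within the scatter), no shift beyond the scatter, giving an estimated 46% with a range from 36% to 56%.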

Compound 4, a percentage reported as inhibition, at one concentration (the size of the read-out at that concentration, not a potency): 49.9%
Compound 4: the middle estimate sits 3.9 percentage points below what was measured; the measured number falls inside the stated range.
By their numbers in this assay, from the lowest: compounds 3, 1, 2 and 4 (each within the scatter of the next, the first and the last beyond it).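

Swapping nitro for methoxycarbonyl on this aromatic carbon, para to a large group, gives the first step beyond the scatter in this assay, a number 10.3 percentage points higher from compound 3 to compound 4 (beyond the scatter), although it is only modest. The other two steps, a number 1.7 percentage points higher from compound 2 to compound 4 (within the scatter) and a number 6 percentage points higher from compound 1 to compound 4 (within the scatter), stay within the scatter, so compound 4 is set apart from compound 3 alone, and not from the ethoxycarbonyl or methoxy compounds. No available evidence accounts for this separation. The compounds shown leave open how a carboxylic acid or an amine on this aromatic carbon would read in this assay.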